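The compounds below may be only part of what the source reports. "The series", "measured", "known", "first", "only" and "open" are said of these compounds alone.

Compound 1 `COc1cc(C)cc(-c2c(-c3ccnc(-c4ccc(C(C)=O)cc4)c3)cnn2CC#N)c1`: > 100000 nM in a functional assay on OVCAR-5 cells (Homo sapiens) for inhibition, read by sulforhodamine B assay, with a stated time of 48 h; on this read-out lower numbers stand for higher toxicity in this test and higher numbers for lower toxicity in this test
Compound 2 `Cc1cc(O)cc(-c2nn(CC#N)cc2-c2ccnc(-c3ccc(Oc4ccccc4)cc3)c2)c1`: 48300 nM

In this assay compound 1 gives only a limit, > 100000 nM, which marks the edge of what the test can report rather than a number. For the measured compounds named here, compound 2 gives 48300 nM, and this is the only real number among the two values shown; the other value is the limit of > 100000 nM in this assay, at which 1 of the 2 values shown sits. Going by the values given here, compound 2 therefore stands alone as the one compound with a measurable effect here, and there is no second number to set it against.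

Compound 3 `Cc1cc(O)cc(-c2nn(CC#N)cc2-c2ccnc(-c3ccc(N(C)C)cc3)c2)c1` has not yet been measured. It differs from compound 2 in one place: dimethylamino in place of phenoxy on an aromatic carbon, in short dimethylamino in place of phenoxy on an aromatic carbon. Among the compounds with values here, no measured pair in this set shows what such a swap does, so the step from compound 2 to compound 3 is expected to be a 1.2-fold higher number from compound 2 to compound 3 (0.09 log units; within the scatter), with a fair chance that it stays within the usual scatter or runs up against the limit. Compound 3 is therefore estimated at about 60000 nM, with a plausible range from 20000 nM to 150000 nM.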

Compound 3, concentration lethal to 50% of the cells: > 100000 nM
Compound 3 ended at the assay's limit; the forecaster's own chance of this, stated with the estimate: 35%; middle value at least 1.6-fold (0.22 log units) away from the limit.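

For the compounds shown here, this is the first pair in the set that differs in one place, and it shows that the group on this aromatic carbon, para to a large group, can move the read-out: dimethylamino in place of phenoxy gives an at least 2.0-fold higher number from compound 2 to compound 3 (0.31 log units; beyond the scatter) in this assay, a shift towards lower toxicity in this test. Compound 3 gives > 100000 nM, which is a limit of the assay and not a number. The step therefore has a known minimum but no known full size, because compound 3 stands at the edge of what the test can report, where it is not alone: the limit of > 100000 nM in this assay, at which 2 of the 3 values shown sit.

The swap removes a six-membered aromatic ring and replaces an oxygen link with a nitrogen at the same time, so this one pair cannot separate what the ring contributes from what the linking atom contributes. Going by these compounds, an ethoxy group, which keeps the oxygen without the ring, and a phenylamino group, which keeps the ring on a nitrogen, would pull these two changes apart, and how either would read in this assay remains open.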